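The source may report more compounds than this note shows. Statements on the series, on what has been measured and on what is new or still open speak of the compounds shown alone.

Compound 1 `O=C1c2ccccc2NS(=O)(=O)N1COCCO` gives 160 ug/mL in a functional assay on HEL cells (Homo sapiens); a higher number here means that more compound is tolerated, a lower number that less compound is tolerated.
Compound 3 `O=C1NS(=O)(=O)N(COCCO)c2ccccc21` gives 112 ug/mL in this assay.
Compound 2 `CC(=O)OCCOCN1c2ccccc2C(=O)NS1(=O)=O` reaches only a limit of this assay, > 200 ug/mL.

Compound 1 holds the highest of the two numbers, with compound 3 nearest, and that gap lies within the scatter, so the two cannot be ordered. Within the data shown here, the only measured step, an at least 1.7-fold lower number from compound 2 to compound 3 (0.25 log units; that floor lies within the scatter), has a floor within the scatter; its upper value sits at the limit of > 200 ug/mL in this assay, at which 1 of the 3 values shown sits. Compound 4 `C#CCOCN1C(=O)c2ccccc2NS1(=O)=O` differs from compound 1 by ethynyl in place of hydroxymethyl on a saturated chain carbon bound to an oxygen on a saturated carbon. Among the measured compounds shown here, no measured step exchanges a group of this kind, and the one measured step touches the same chain end without a change beyond the scatter, so the expected step in this assay is a 1.1-fold lower number from compound 1 to compound 4 (0.03 log units; within the scatter), none beyond the scatter. Compound 4 is therefore estimated at 150 ug/mL, between 80 ug/mL and 200 ug/mL.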

Compound 4, half-maximal cytotoxic concentration: 169 ug/mL
Estimate against measurement, compound 4: 1.1-fold (0.05 log units) below; the range from low to high includes it.
By their numbers in this assay, from the lowest: compounds 3, 1 and 4 (each within the scatter of the next). At a limit, above all of these: compound 2.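

Going from hydroxymethyl to ethynyl at this chain end gives a 1.1-fold higher number from compound 1 to compound 4 (0.02 log units; within the scatter) in this assay. The earlier compounds shown here only showed this end with its hydroxyl free or acetylated, whereas here the hydroxymethyl, with its hydrogen-bond donor and acceptor, gives way to a group with neither, and no change beyond the scatter appears.

As far as these compounds go, whether an amine, a carboxylic acid or a longer chain at this place would move the number beyond the scatter stays open. Compound 2 remains a limit, so its distance from the others is also open: the limit of > 200 ug/mL in this assay, at which 1 of the 4 values shown sits.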